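Cinnamic acid triazole series: phenyl in place of fluorophenyl

The compounds below may be only part of what the source reports. "The series", "measured", "known", "first", "only" and "open" are said of these compounds alone.

The series shares one core, carried in compound 1 `COc1ccc(/C=C\C(=O)O)c(OCc2cn(-c3ccc(NC(C)=O)cc3)nn2)c1CC=C(C)C` with an acetanilide on the triazole, in compound 2 `COc1ccc(/C=C\C(=O)O)c(OCc2cn(-c3ccc(NC(=O)c4ccccc4)cc3)nn2)c1CC=C(C)C` with a benzanilide at the same position, and in compound 3 `COc1ccc(/C=C\C(=O)O)c(OCc2cn(-c3ccccc3F)nn2)c1CC=C(C)C` with a 2-fluorophenyl group on the triazole nitrogen. In a functional assay on A549 cells (Homo sapiens) for cytotoxicity, read by MTT assay, with a stated time of 24 h (on this read-out higher numbers stand for weaker inhibition and lower numbers for stronger inhibition), compound 2 gives 42700 nM, a weak effect on this read-out. In this assay the entry for compound 1 is "not determined" (no result reported), and the entry for compound 3 is "not determined" (no result reported), so compound 3 stands without a value of its own; it is known only by its structure, and the single measured point of the series is that of compound 2. Compound 4 `COc1ccc(/C=C\C(=O)O)c(OCc2cn(-c3ccccc3)nn2)c1CC=C(C)C` differs from compound 3 by hydrogen in place of fluoro on an aromatic carbon. Among the measured compounds shown here, no step between measured compounds is available in this assay, so the size and direction of this step cannot be read from the data; the only anchor is the weak cytotoxicity of compound 2. The step from the fluorinated to the unsubstituted phenyl group is expected to change this assay by no more than the usual scatter. Compound 4 is therefore estimated at 45000 nM, with a range from 15000 nM to 150000 nM, and a fair chance that this assay reports only a limit for it.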

Compound 4, half-maximal inhibitory concentration: 40500 nM
Compound 4: the middle estimate sits 1.1-fold (0.05 log units) above what was measured; measured number inside the range.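

In this assay, the series now has its first readable step at this place on the aromatic ring, a 1.1-fold lower number from compound 2 to compound 4 (0.02 log units; within the scatter), and it lies within the scatter. On this read-out, the benzamido group and hydrogen on this aromatic carbon cannot be told apart, so the large anilide extension of compound 2 is not needed for the weak cytotoxicity, and the plain phenyl group of compound 4 sits at the same level. No measurement on hand bears on why this change leaves the read-out flat.

The steps that would start from compound 1 or compound 3 cannot be read, so the acetamido group and the fluoro group remain without a measured effect in this assay. Also open, on these data alone, is whether an amine or a carboxylic acid on this phenyl ring, or a change in the shared core away from the triazole substituent, would move the read-out beyond the scatter.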